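Ethyl removed from the amine nitrogen of the series lead

A few compounds are considered here, and "the series" means these few. Any claim that something is new, unique, unknown or untested is made for them only; others in the source may bear on it.

Of the compounds shown here, two have been measured in an assay on isolated protein for inhibition of ubiquitin carboxyl-terminal hydrolase 7 (Homo sapiens), with stated times of 30 min and 2 h; a lower number here means a stronger inhibitor, a higher number a weaker inhibitor. Compound 1 `Cn1nc2c(=O)n(CC3(O)CCN(Cc4ccc(-c5ccc[nH]5)cc4Cl)CC3)cnc2c1-c1ccc(CN)cc1` gives 193 nM. Compound 2 `CCNCc1ccc(-c2c3ncn(CC4(O)CCN(Cc5ccc(-c6ccco6)cc5Cl)CC4)c(=O)c3nn2C)cc1` gives 15.2 nM, the lower of the two numbers; the gap between compound 2 and compound 1 lies beyond the usual scatter, but the two differ in more than one place, so no single change can be credited. Compound 3 `Cn1nc2c(=O)n(CC3(O)CCN(Cc4ccc(-c5ccco5)cc4Cl)CC3)cnc2c1-c1ccc(CN)cc1` is not yet measured in this assay. It differs from compound 2 in one place: hydrogen in place of ethyl on an amine nitrogen. With no measured step of this kind in the series, the direction is open; the expected change from compound 2 to compound 3, a 2.6-fold higher number from compound 2 to compound 3 (0.42 log units; beyond the scatter), is a modest weakening, with a shift within the scatter also possible. The value expected for compound 3 in this assay is 40 nM, in the range 12 nM to 130 nM.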

Compound 3, half-maximal inhibitory concentration: 18.1 nM
For compound 3 the middle estimate is 2.2-fold (0.34 log units) above the measured one; the measured number falls inside the stated range.
By their numbers in this assay, from the lowest: compounds 2 and 3 (each within the scatter of the next); then compound 1.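

In this assay, the ethyl on the amine nitrogen is not needed for the number to hold: ethylamino to amino gives a 1.2-fold higher number from compound 2 to compound 3 (0.08 log units; within the scatter), which lies within the scatter. Among the compounds shown here, a second single change can now be read too: furan-2-yl in place of 1H-pyrrol-2-yl on an aromatic carbon gives an 11-fold lower number from compound 1 to compound 3 (1.03 log units; beyond the scatter), so of the two changes separating the earlier pair, only this one carries a step beyond the scatter. No measurement at hand bears on the reason for either result.

As far as these compounds go, on the amine nitrogen, only hydrogen and ethyl can be compared, so the outcome with a longer chain, an isopropyl or an acetyl there remains open. On the aromatic carbon, only furan-2-yl and 1H-pyrrol-2-yl can be compared, leaving a thiophen-2-yl or a phenyl group open.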